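Removing one methoxy group: two matched steps

This account rests on a few compounds, and the source may have more. Where it says the series, first, only, none or still open, it means among the compounds named here.

Measured compounds:
compound 1, `COc1cc(/C=C2\CN(CC(=O)O)c3c(C)cccc3C2=O)cc(OC)c1OC`, 0.85%
compound 2, `COc1ccc(/C=C2\CN(CC(=O)O)c3c(C)cccc3C2=O)c(OC)c1OC`, 1.57%
compound 3, `COc1cc(/C=C2\CN(CC(=O)O)c3c(C)cccc3C2=O)cc(OC)c1`, 32.3%

All three were run in an assay on HL-60 cells for inhibition of glutathione S-transferase P (Homo sapiens), read by spectrophotometry, tested at 20 uM; on this read-out lower numbers stand for less inhibition and higher numbers for more inhibition at the one concentration tested (going by the name of the read-out). Compound 1 and compound 2 are built from the same atoms joined differently; the difference between the two cores is not broken down here. Their read-outs lie within the usual scatter of each other, so no order between them is claimed.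

From compound 1 to compound 3 the change is hydrogen in place of methoxy on an aromatic carbon, and it gives a number 31.5 percentage points higher from compound 1 to compound 3 (beyond the scatter). Within the data shown here, this is the only step on which a pattern can rest.

Compound 4, `COc1ccc(/C=C2\CN(CC(=O)O)c3c(C)cccc3C2=O)c(OC)c1`, is not yet measured. It differs from compound 2 by hydrogen in place of methoxy on an aromatic carbon. This is the same kind of change as from compound 1 to compound 3, not the same: in compound 1 the leaving methoxy sits para to a large group, in compound 2 meta to it.

Because compound 2 gives 1.57%, close to compound 1, and because the matched step is a number 31.5 percentage points higher from compound 1 to compound 3 (beyond the scatter), the step from compound 2 to compound 4 is expected to be a number 23.4 percentage points higher from compound 2 to compound 4 (beyond the scatter), taken with wide uncertainty since the surroundings differ. Compound 4 is estimated at 25%, between 4% and 45%.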

Compound 4, a percentage reported as inhibition, at one concentration (the size of the read-out at that concentration, not a potency): 11.7%
The estimate for compound 4 lay 13.3 percentage points above the measured number; measured number inside the range.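

In this assay, hydrogen in place of methoxy gives a number 10.1 percentage points higher from compound 2 to compound 4 (beyond the scatter), so the direction of the step on the core of compound 1 recurs on this second core. The size of the step does not carry over, and the two steps differ clearly: the same change on two cores in this assay, a number 31.5 percentage points higher (beyond the scatter) from compound 1 to compound 3 and a number 10.1 percentage points higher (beyond the scatter) from compound 2 to compound 4, 21.3 percentage points apart, beyond the scatter of two such steps. These two pairs show the same direction and no more; they do not show what sets the size of the step, and they give no fixed increment that could be carried to a further core in this series.

The compounds shown carry only methoxy groups or hydrogen on this aromatic ring, which leaves open how a hydroxy group, a fluorine or an amine would read in the place of the methoxy that leaves. Also open, from the compounds shown here alone, is whether the same step would hold with an amide in place of the carboxylic acid.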